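Replacing pyridin-4-yl with thiophen-3-yl: a tolerance forecast

The compounds below may be only part of what the source reports. "The series", "measured", "known", "first", "only" and "open" are said of these compounds alone.

How much of a compound cells can bear before they die is a basic safety question, and an ADME assay on Huh-7 cells (Homo sapiens) for cytotoxicity, read by MTT assay, with a stated time of 96 h (a lower number here means that less compound is tolerated, a higher number that more compound is tolerated), puts a number on it. Compound 1 (`COc1ccc(-c2cnco2)cc1NCc1cccs1`) is reported only as a limit, > 100000 nM. Within the data shown here, compound 2 (`COc1cc(NCc2ccncc2)ccc1-c1cnco1`) gives 72200 nM in this assay, which makes it the only true number available so far.

Compound 3 (`COc1cc(NCc2ccsc2)ccc1-c1cnco1`) keeps everything in compound 2 except one group: thiophen-3-yl stands in place of pyridin-4-yl on a saturated chain carbon bound to a nitrogen on an aromatic ring (thiophen-3-yl in place of pyridin-4-yl on a saturated chain carbon bound to a nitrogen on an aromatic ring). Among the measured compounds shown here, no two measured compounds differ in just one place, so the data give no direct size for a change of this kind. The forecast therefore starts from compound 2 at 72200 nM, and no clear direction can be argued. The expected step of a 1.0-fold lower number from compound 2 to compound 3 (0.01 log units; within the scatter) is none beyond the usual scatter. Compound 3 is expected at 70000 nM, with an estimated range from 30000 nM to 100000 nM.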

Compound 3, half-maximal cytotoxic concentration: 63100 nM
The estimate for compound 3 lay 1.1-fold (0.05 log units) above the measured number, within the range that was stated.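

Among these compounds, this is the first direct measure of a change at this place, on a saturated chain carbon bound to a nitrogen on an aromatic ring. In this assay, putting thiophen-3-yl in place of pyridin-4-yl gives a 1.1-fold lower number from compound 2 to compound 3 (0.06 log units; within the scatter), so a five-membered aromatic ring holding sulfur and a six-membered aromatic ring holding nitrogen cannot be told apart here. This single pair sets no general rule, and it was read close to the top of what the assay can report, which leaves limited room to see any rise in the tolerated amount: the limit of > 100000 nM in this assay, at which 1 of the 3 values shown sits.

What the compounds shown leave open is whether a group of another kind at this place, such as a saturated cyclohexyl ring, an amine such as piperidin-4-yl, or a carboxylic acid, would bring the number down clearly. On these data alone, it is also open whether a longer chain between the nitrogen and the ring would change the reading, and whether the same ring exchange would stay this quiet on a different core.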